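Ethoxy on the Anilide Ring: Cytotoxicity Toward Normal Colon Cells

A few compounds are considered here, and "the series" means these few. Any claim that something is new, unique, unknown or untested is made for them only; others in the source may bear on it.

Measured compounds:
compound 1, `O=C(Nc1ccccc1)c1cccc(/C=C2\CC(=O)N(c3ccccc3)C2=O)c1`, > 100000 nM
compound 2, `CCc1cccc(NC(=O)c2cccc(/C=C3\CC(=O)N(Cc4ccccc4)C3=O)c2)c1`, > 100000 nM

The series shares a core in which an anilide is linked through an exocyclic alkene to a cyclic imide. In an ADME assay on NCM460 cells (Homo sapiens) for cytotoxicity, read by MTT assay, with a stated time of 72 h (a higher number here means a weaker inhibitor, a lower number a stronger inhibitor), compound 1 gives > 100000 nM, which is a limit of the assay and not a number. In this assay compound 2 also gives > 100000 nM, again a limit rather than a number. Among the measured compounds shown here, compound 1 therefore stands at the top of what this assay can report, and it shares that position with the only other measured compound; both values sit on (the limit of > 100000 nM in this assay, at which 2 of the 2 values shown sit).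

The next compound, compound 3, is `CCOc1ccc(NC(=O)c2cccc(/C=C3\CC(=O)N(c4ccccc4)C3=O)c2)cc1`. It differs from compound 1 by ethoxy in place of hydrogen on an aromatic carbon.

For the measured compounds named here, no measured pair here separates the effect of an ethoxy group on the anilide ring. Going by the values given here, both measured compounds stay at the same limit, and that is the only guide available. The step of a number no higher from compound 1 to compound 3 (the limit leaves the size open) is expected to be none beyond the scatter. Compound 3 is therefore expected to give about 100000 nM, within 30000 nM to 300000 nM, most likely reported once more as a limit.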

Compound 3, half-maximal inhibitory concentration: > 100000 nM
Compound 3 ended at the assay's limit (the forecaster's own chance of this, stated with the estimate: 80%); the middle value lies on the limit itself.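

In this assay compound 3 gives > 100000 nM, which is a limit of the assay and not a number. Compound 1 also sits at a limit, so no step can be read between compound 1 and compound 3. The compounds shown leave open whether any of them has a measurable half-maximal inhibitory concentration in this assay.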